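Benzyl substituent and cytotoxicity in a triazole-linked chromenone series

This account rests on a few compounds, and the source may have more. Where it says the series, first, only, none or still open, it means among the compounds named here.

Measured compounds in a functional assay on QGY7701 cells (Homo sapiens) for cytotoxicity, read by MTT assay, with a stated time of 48 h; a higher number here means a weaker inhibitor, a lower number a stronger inhibitor:
compound 1 `Cc1cccc(Cn2cc(COc3ccc4c(=O)ccoc4c3)nn2)c1`: 22400 nM
compound 2 `O=c1ccoc2cc(OCc3cn(Cc4ccc(Cl)cc4)nn3)ccc12`: 41700 nM
compound 3 `Cc1ccccc1Cn1cc(COc2ccc3c(=O)ccoc3c2)nn1`: a limit only, > 100000 nM

Compound 3 stands only at a limit in this assay, (the limit of > 100000 nM in this assay, at which 1 of the 3 values shown sits), with no number inside the range. The step to compound 4 `O=c1ccoc2cc(OCc3cn(Cc4cccc(Cl)c4)nn3)ccc12` is 3-chlorophenyl in place of 2-methylphenyl on a saturated chain carbon bound to an aromatic nitrogen. Within the data shown here, two measured steps bear on it: an at least 4.4-fold higher number from compound 1 to compound 3 (0.64 log units; beyond the scatter) and an at least 2.3-fold higher number from compound 2 to compound 3 (0.37 log units; beyond the scatter), both moving onto the 2-methylphenyl and both beyond the scatter, while a 1.9-fold higher number from compound 1 to compound 2 (0.27 log units; within the scatter) is within it. Leaving the 2-methylphenyl for a 3-chlorophenyl is therefore expected to bring the number back down, a step of about an at least 3.3-fold lower number from compound 3 to compound 4 (0.52 log units; beyond the scatter). Compound 4 is estimated at 30000 nM, within 12000 nM to 80000 nM.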

Compound 4, half-maximal inhibitory concentration: 28400 nM
The estimate for compound 4 lay 1.1-fold (0.02 log units) above the measured number, and the stated range covers the measured number.
By their numbers in this assay, from the lowest: compounds 1, 4 and 2 (each within the scatter of the next). At a limit, above all of these: compound 3.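

In this assay the change away from the 2-methylphenyl gives an at least 3.5-fold lower number from compound 3 to compound 4 (0.54 log units; beyond the scatter), a step read against a limit for compound 3: the limit of > 100000 nM in this assay, at which 1 of the 4 values shown sits.

Chloro in place of methyl and moving the chloro on the phenyl both stay within the scatter: a 1.3-fold higher number from compound 1 to compound 4 (0.10 log units; within the scatter), and a 1.5-fold lower number from compound 2 to compound 4 (0.17 log units; within the scatter). Among these four benzyl groups, only the 2-methylbenzyl of compound 3 stands apart.

On these data alone, whether a 2-chlorophenyl would also reach a limit remains open, so the series cannot separate the methyl from its placement on the ring. As far as these compounds go, a phenyl carrying an amine or a carboxylic acid also remains untested here.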